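The source may report more compounds than this note shows. Statements on the series, on what has been measured and on what is new or still open speak of the compounds shown alone.

Compound 3 `COC(C(=O)O)c1nn(Cc2cn3cc(OCC4CC4)c(Cl)cc3n2)c2ccccc2c1=O` gives 217 nM in a functional assay on HFL1 cells for antagonist activity at sphingosine 1-phosphate receptor 2 (Homo sapiens), read by ELISA, with a stated time of 24 h, in the presence of a further agent that is not named here; a lower number here means a stronger inhibitor, a higher number a weaker inhibitor. It stands second highest of the three numbers measured: compound 1 `CC(C)(C(=O)O)c1nn(Cc2cn3cc(OCC4CC4)c(Cl)cc3n2)c2ccccc2c1=O`, with 361 nM, is nearest, and the step of a 1.7-fold lower number from compound 1 to compound 3 (0.22 log units; within the scatter) lies within the scatter, while compound 2 `C[C@H](C(=O)O)c1nn(Cc2cn3cc(OCC4CC4)c(Cl)cc3n2)c2ccccc2c1=O`, with 19 nM, is furthest, the step of an 11-fold higher number from compound 2 to compound 3 (1.06 log units; beyond the scatter) being large. Compound 4 `CC(C(=O)O)c1nn(Cc2cn3cc(OCC4CC4)c(Cl)cc3n2)c2ccccc2c1=O` differs from compound 3 in one place: methyl in place of methoxy on a saturated chain carbon bound to an aromatic carbon and a carbonyl carbon. Among the measured compounds shown here, the step that bears on this is the one from compound 2 to compound 3, read in reverse; compound 4 carries the same 1-carboxyethyl group as compound 2 without its defined configuration. A large lowering of the number is therefore expected, a 6.8-fold lower number from compound 3 to compound 4 (0.83 log units; beyond the scatter), with compound 4 estimated at 32 nM (range 12 nM to 85 nM).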

Compound 4, half-maximal inhibitory concentration: 15 nM
For compound 4 the middle estimate is 2.1-fold (0.33 log units) above the measured one; measured number inside the range.
By their numbers in this assay, from the lowest: compounds 4 and 2 (each within the scatter of the next); then compounds 3 and 1 (each within the scatter of the next).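

In this assay, the saturated chain carbon bound to an aromatic carbon and a carbonyl carbon proves sensitive to what it carries: methyl in place of methoxy gives a 14-fold lower number from compound 3 to compound 4 (1.16 log units; beyond the scatter), and hydrogen in place of methyl on the 1-carboxy-1-methylethyl group gives a 24-fold lower number from compound 1 to compound 4 (1.38 log units; beyond the scatter). Drawing the stereocentre or leaving it undefined changes nothing beyond the scatter, with a 1.3-fold lower number from compound 2 to compound 4 (0.10 log units; within the scatter), and this comparison carries one limit: the fact that one of compounds 2 and 4 is drawn with a defined configuration and the other without, at the place where they differ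

Still open, going by these compounds, is how the opposite configuration to compound 2 would read, and whether an ethyl group, a hydroxyl group or a fluorine on this carbon would match methyl.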